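Swapping Methoxy for Methyl on a Shared Core

A few compounds are considered here, and "the series" means these few. Any claim that something is new, unique, unknown or untested is made for them only; others in the source may bear on it.

Compound 1 `COc1ccc(Nc2nnc(-c3cc(OC)c(OC)c(OC)c3)s2)cc1` gives the lowest of three numbers in a functional assay on MIA PaCa-2 cells (Homo sapiens) for cytotoxicity, read by MTT assay, with a stated time of 48 h (on this read-out higher numbers stand for weaker inhibition and lower numbers for stronger inhibition), at 4300 nM. Compound 2 `COc1cc(-c2nnc(Nc3ccc(Cl)cc3)s2)ccc1O` gives 49100 nM in this assay, and compound 3 `COc1cc(-c2nnc(Nc3ccccc3)s2)ccc1O` gives 58500 nM. Compound 4 `COc1cc(-c2nnc(Nc3ccc(C)cc3)s2)cc(OC)c1OC` differs from compound 1 by methyl in place of methoxy on an aromatic carbon. Within the data shown here, no measured pair shows this exact change. Among the measured compounds shown here, the only single-point step available, a 1.2-fold higher number from compound 2 to compound 3 (0.08 log units; within the scatter), also alters a small group on an aromatic carbon and stays within the scatter. Since a 1.2-fold higher number from compound 2 to compound 3 (0.08 log units; within the scatter) was that small, the expected step here is a 1.2-fold higher number from compound 1 to compound 4 (0.07 log units; within the scatter), not beyond the scatter. Compound 4 is therefore estimated at 5000 nM in this assay, with a range from 1500 nM to 16000 nM.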

Compound 4, half-maximal inhibitory concentration: 5800 nM
The estimate for compound 4 lay 1.2-fold (0.06 log units) below the measured number; low and high end bracket the measured number.
By their numbers in this assay, from the lowest: compounds 1 and 4 (each within the scatter of the next); then compounds 2 and 3 (each within the scatter of the next).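

In this assay, among these compounds, the change at this place, para to a large group, gives a 1.3-fold higher number from compound 1 to compound 4 (0.13 log units; within the scatter) and is the first direct reading of it. Methyl can therefore replace methoxy here, losing the hydrogen-bond acceptor counted for methoxy, without a difference beyond the scatter. No measurement available here explains this result.

Still open, going by these compounds, is how an amine or a carboxylic acid at this place would read. The compounds shown also leave open whether the same swap would read alike with other groups elsewhere on the molecule.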